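The source may report more compounds than this note shows. Statements on the series, on what has been measured and on what is new or still open speak of the compounds shown alone.

Three closely related compounds have been measured in a physicochemical assay for lipophilicity, read by HPLC, at pH 7.5; on this read-out higher numbers stand for higher lipophilicity and lower numbers for lower lipophilicity. Compound 1 `CC[C@@H](Nc1c(C#N)c(-c2ccc(-c3cccc(C)c3)cc2)nc2cnccc12)C(N)=O` gives 3, compound 2 `CC[C@@H](Nc1c(C#N)c(-c2ccc(-c3cccc(CO)c3)cc2)nc2cnccc12)C(N)=O` gives 2, and compound 3 `CC[C@@H](Nc1c(C#N)c(-c2ccc(-c3ccccc3COC)cc2)nc2cnccc12)C(N)=O` gives 2.6. That makes compound 3 the second highest of the three numbers, with clear gaps on both sides.

Compound 4 `CC[C@@H](Nc1c(C#N)c(-c2ccc(-c3cccc(Cl)c3)cc2)nc2cnccc12)C(N)=O` has not yet been measured. It carries 3-chlorophenyl in place of 2-(methoxymethyl)phenyl on an aromatic carbon, para to a large group: 3-chlorophenyl in place of 2-(methoxymethyl)phenyl on an aromatic carbon.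

The most relevant measured change is a number 0.40 log units lower from compound 1 to compound 3 (beyond the scatter), where the same 2-(methoxymethyl)phenyl replaced 3-methylphenyl. Going by the values given here, the new change removes that group again, but 3-chlorophenyl enters instead of 3-methylphenyl, and no measured compound contains chlorine. The other two changes help less. One is a number 1.00 log units lower from compound 1 to compound 2 (beyond the scatter), and the other is a number 0.60 log units higher from compound 2 to compound 3 (beyond the scatter). Neither involves 3-chlorophenyl, but together they show that changes on this outer ring have moved the number by modest amounts.

If compound 4 lands near compound 1, at 3, a modest upward step is expected, beyond the scatter. The expected step is a number 0.50 log units higher from compound 3 to compound 4 (beyond the scatter). In this assay, the estimate for compound 4 is 3.1, with an expected range from 2.7 to 3.5.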

Compound 4, distribution coefficient: 3.1
The estimate for compound 4 equals the measured number at the digits printed; the range from low to high includes it.
By their numbers in this assay, from the lowest: compound 2; then compound 3; then compounds 1 and 4 (each within the scatter of the next).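

In this assay, replacing methyl with chloro on the outer ring gives a number 0.10 log units higher from compound 1 to compound 4 (within the scatter), so this read-out does not separate these two groups at this position. Chloro in place of hydroxymethyl gives a number 1.10 log units higher from compound 2 to compound 4 (beyond the scatter), the only step so far printed as large, and across these four compounds the two whose outer-ring group contains oxygen, compound 2 and compound 3, give the lower numbers, with no compound going against this. The change from 2-(methoxymethyl)phenyl to 3-chlorophenyl gives a number 0.50 log units higher from compound 3 to compound 4 (beyond the scatter), but it alters both the group and where it sits on the ring, so this step alone cannot show how much each contributes.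

Nothing available here explains why these numbers differ. The compounds shown also leave open how the read-out would respond to an amine or a carboxylic acid on this outer ring, groups that could show whether the pattern holds beyond the neutral groups seen so far.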